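Side-chain variation and HeLa tolerance in the series

The source may report more compounds than this note shows. Statements on the series, on what has been measured and on what is new or still open speak of the compounds shown alone.

Compound 2 `CS(=O)(=O)CCCn1c(Cn2c(=O)n(C3CC3)c3ccncc32)nc2nc(Cl)ccc21` carries a 3-(methylsulfonyl)propyl chain on the shared core. In an ADME assay on HeLa cells (Homo sapiens) for cytotoxicity, read by ATP content, with a stated time of 3 days (a higher number here means that more compound is tolerated, a lower number that less compound is tolerated), compound 2 gives > 50000 nM, which is a limit of the assay and not a number. Compound 1 `CC(C)(O)CCCn1c(Cn2c(=O)n(C3CC3)c3ccncc32)nc2nc(Cl)ccc21` is the closest measured relative. In this assay compound 1 gives > 50000 nM, likewise a limit. The step that the two limits leave unreadable from compound 1 to compound 2 therefore cannot be sized; both values sit at the same boundary (the limit of > 50000 nM in this assay, at which 2 of the 2 values shown sit). Compound 3 `O=c1n(Cc2nc3nc(Cl)ccc3n2CCCCO)c2cnccc2n1C1CC1` differs from compound 2 by hydroxymethyl in place of methylsulfonyl on a saturated chain carbon, three bonds along the chain from an aromatic nitrogen. For the measured compounds named here, no measured step bears on this exchange beyond the unreadable one from compound 1 to compound 2, so no step beyond the scatter is expected in this assay, and the most likely outcome is another limit. Compound 3 is expected to give 70000 nM in this assay, between 30000 nM and 200000 nM. This corresponds to an expected step that the limit leaves unreadable from compound 2 to compound 3.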

Compound 3, half-maximal cytotoxic concentration: > 50000 nM
Compound 3: no number, only a limit; the forecaster's own chance of this, stated with the estimate: 85%; the middle value is on the limit's open side.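

For the compounds shown here, no step among compound 1, compound 2 and compound 3 can be read in this assay, since all three values are limits and not numbers: the limit of > 50000 nM in this assay, at which 3 of the 3 values shown sit.

The compounds shown leave open where the half-maximal cytotoxic concentration of each of these side chains actually lies, and whether any chain on the shared core would bring it within range.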